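The source may hold more compounds than are shown below. What is called first, only, known or untested is meant among the compounds shown, and "the series" means these compounds.

Measured so far:
- compound 1 `COc1ccc([C@@H]2C/C(=N/OCc3cn(-c4ccc(O)cc4)nn3)c3cc(CC=C(C)C)c(OC)cc3O2)cc1`: 52%
- compound 2 `COc1ccc([C@@H]2C/C(=N/OCc3cn(-c4ccc(C(=O)c5ccccc5)cc4)nn3)c3cc(CC=C(C)C)c(OC)cc3O2)cc1`: 34%

In a functional assay on A549 cells (Homo sapiens) for inhibition, read by sulforhodamine B assay, with a stated time of 48 h, tested at 50 uM (a higher number here means more inhibition of growth at the concentration tested, a lower number less inhibition of growth), compound 2 gives 34%, the lower of the two numbers available, while compound 1 gives 52%. The next compound, compound 3 `COc1ccc([C@@H]2C/C(=N/OCc3cn(-c4ccc(C#N)cc4)nn3)c3cc(CC=C(C)C)c(OC)cc3O2)cc1`, keeps the shared core of compound 2 and alters one group: cyano in place of benzoyl on an aromatic carbon. The cyano group therefore sits on an aromatic carbon, para to a large group.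

Among the measured compounds shown here, only one measured step bears on this change. It is a number 18 percentage points lower from compound 1 to compound 2 (beyond the scatter), a modest move that came with benzoyl taking the place of hydroxy at this same carbon. Compound 3 also loses the benzoyl, so some recovery towards compound 1 seems likely. Cyano is not hydroxy, however, and no measured compound yet shows how cyano behaves here, so only part of that drop is expected to return. The expected change is a number 9 percentage points higher from compound 2 to compound 3 (within the scatter), and it may not clear the usual scatter.

For compound 3, the estimated value is 43%, with an expected range from 28% to 58%.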

Compound 3, percent growth inhibition at one concentration: 42%
Compound 3: the middle estimate sits 1 percentage points above what was measured, within the range that was stated.
By their numbers in this assay, from the lowest: compounds 2, 3 and 1 (each within the scatter of the next, the first and the last beyond it).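

In this assay the change to cyano gives a number 8 percentage points higher from compound 2 to compound 3 (within the scatter) and, set against hydroxy, a number 10 percentage points lower from compound 1 to compound 3 (within the scatter) so on this aromatic carbon cyano cannot be told apart from either of the other two groups. Those two groups do stand apart, with a number 18 percentage points lower from compound 1 to compound 2 (beyond the scatter) and compound 3 now fills that gap without being separable from either end, so the three compounds form no clean order and only the two outer groups differ beyond the scatter. The loss of benzoyl, with its aromatic ring, thus gives no clear gain over compound 2, and nothing measured here explains why the numbers fall as they do.

The compounds shown leave open whether another group on this carbon, such as an amine or a carboxylic acid, would give a number clearly apart from compound 2 or compound 1. Among the compounds shown here, they also leave open whether the hydroxy of compound 1 is distinctive at this carbon or is only one of several groups that give a similar number, and whether the same picture would hold at other concentrations.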